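The compounds below may be only part of what the source reports. "The series", "measured", "known", "first", "only" and "open" are said of these compounds alone.

Of the compounds shown here, three sharing one core have been measured in a physicochemical assay for solubility, read by HPLC, with a stated time of 24 h; on this read-out higher numbers stand for higher solubility and lower numbers for lower solubility. Compound 3, `COC(=O)NC[C@H]1CN(c2ccc(-n3cc(-c4ccccn4)cn3)c(F)c2)C(=O)O1`, gives 34100 nM. Compound 1, `O=C1O[C@@H](CO)CN1c1ccc(-n2cc(-c3ccccn3)cn2)c(F)c1`, gives 56400 nM, and compound 2, `O=C1CCC(=O)N1C[C@H]1CN(c2ccc(-n3cc(-c4ccccn4)cn3)c(F)c2)C(=O)O1`, gives 45300 nM. On these numbers compound 3 holds the lowest value, yet the gaps are small: a 1.7-fold lower number from compound 1 to compound 3 (0.22 log units; within the scatter) and a 1.3-fold lower number from compound 2 to compound 3 (0.12 log units; within the scatter), and between the other two a 1.2-fold lower number from compound 1 to compound 2 (0.10 log units; within the scatter). None of these steps exceeds the scatter, so the three compounds cannot be told apart with confidence.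

Compound 4, `CCNC(=O)NC[C@H]1CN(c2ccc(-n3cc(-c4ccccn4)cn3)c(F)c2)C(=O)O1`, differs from compound 3 in one place: ethylamino in place of methoxy on a carbonyl carbon. The measured steps that bear on this are those from compound 1 and compound 2 to compound 3, which exchanged the whole group on the saturated chain carbon, a larger alteration than the one here, and still stayed within the scatter. The expectation for compound 4 is therefore a step of no real size in this assay, a 1.1-fold lower number from compound 3 to compound 4 (0.03 log units; within the scatter). Compound 4 is estimated at 32000 nM, expected to fall between 16000 nM and 64000 nM.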

Compound 4, solubility: 222000 nM
Beside the measured number, compound 4's estimate is 6.9-fold (0.84 log units) below it; the whole stated range lies below it.
By their numbers in this assay, from the lowest: compounds 3, 2 and 1 (each within the scatter of the next); then compound 4.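

Ethylamino in place of methoxy on a carbonyl carbon gives a 6.5-fold higher number from compound 3 to compound 4 (0.81 log units; beyond the scatter) in this assay, the first step in this set to pass beyond the scatter, so a small exchange at this outer end of the side chain can count for more than the whole-group exchanges seen earlier. The same holds against the other two compounds, with a 4.9-fold higher number from compound 2 to compound 4 (0.69 log units; beyond the scatter) and a 3.9-fold higher number from compound 1 to compound 4 (0.60 log units; beyond the scatter), which sets the (ethylcarbamoyl)amino group apart from all three other groups on the saturated chain carbon. No measurement shown speaks to what lies behind this rise.

Going by these compounds, it remains open whether the ethyl chain or the incoming nitrogen with its hydrogen carries the step. A plain amino group, a methylamino group or a longer chain such as propylamino on the same carbonyl carbon would begin to separate the two.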